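Pyridin-3-yl Ether in Place of Fluorophenyl Ether

A few compounds are considered here, and "the series" means these few. Any claim that something is new, unique, unknown or untested is made for them only; others in the source may bear on it.

Compound 3 `CC(=O)N1CCCn2nc(COc3ccccc3F)cc21` gives 60% in a functional assay on HEK293 cells for positive allosteric modulation of metabotropic glutamate receptor 5 (Homo sapiens), read by calcium flux (a lower number here means a smaller maximal response, a higher number a larger maximal response), the highest of the three numbers measured. Compound 1 `CC(C)C(=O)N1CCCn2nc(COc3ccccc3)cc21` gives 59%, which lies within the scatter of compound 3. Compound 2 `O=C(c1nccs1)N1CCCn2nc(COc3ccccc3)cc21` gives 24%, beyond the scatter below compound 3. For the measured compounds named here, the only step between compounds that differ in one place is a number 35 percentage points lower from compound 1 to compound 2 (beyond the scatter), and it sits on the carbonyl carbon, not at the ether end. Compound 4 `CC(=O)N1CCCn2nc(COc3cccnc3)cc21` differs from compound 3 at that ether end: pyridin-3-yl in place of 2-fluorophenyl on an oxygen on a saturated carbon. Going by the values given here, no measured step involves this part of the molecule, so nothing in the data shows that a change there moves the maximal response. Compound 1 and compound 3, which differ at the aromatic ring and at the carbonyl together, show values within the scatter of each other. The step of a number 5 percentage points lower from compound 3 to compound 4 (within the scatter) is therefore expected not to go beyond the scatter. For compound 4 the estimated value is 55%, with a range from 35% to 75%.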

Compound 4, largest response reached (reported as percent of maximum), in percent of the reference or control that the assay uses: < 15%
Compound 4 ended at the assay's limit (the forecaster's own chance of this, stated with the estimate: 0%); middle value at least 40 percentage points away from the limit.
By their numbers in this assay, from the lowest: compound 2; then compounds 1 and 3 (each within the scatter of the next). At a limit, below all of these: compound 4.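

For the compounds shown here, the ether end turns out to be a place where a single change can move the maximal response in this assay: the step at this position is a number at least 45 percentage points lower from compound 3 to compound 4 (beyond the scatter), whereas the earlier compounds offered a measured step only on the carbonyl carbon. Compound 4 gives < 15%, which is a limit of the assay and not a number. The step therefore fixes only a minimum size for the change from 2-fluorophenyl to pyridin-3-yl, because compound 4 stands at that limit: the limit of < 15% in this assay, at which 1 of the 4 values shown sits.

From the compounds shown here alone, it remains open whether the loss of the fluorine or the entry of the ring nitrogen carries the step, and plain phenyl on that oxygen, with the rest of compound 3 kept, would separate the two. Also open, going by these compounds, is how pyridin-2-yl or pyridin-4-yl would behave in the same place.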